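A few compounds are considered here, and "the series" means these few. Any claim that something is new, unique, unknown or untested is made for them only; others in the source may bear on it.

Working notes on the series. In a functional assay on the whole organism with Rattus norvegicus as the target, at a dose of 100 mg/kg (a higher number here means more inhibition at the dose given (going by the name of the read-out), a lower number less inhibition), compound 1 `C/N=C(/NC#N)NCCCCn1nc(N(C)C)ccc1=O` gives 26.3%. In this assay compound 3 `CC/N=C(/NC#N)NCCCn1nc(C)ccc1=O` gives 34.5%. In this assay compound 2 `CC/N=C(\S)NCCCCCCn1nc(-c2ccccc2)ccc1=O` gives -5.6%, the lowest of the three numbers; its gap to compound 1 and its gap to compound 3 both lie beyond the scatter, so compound 2 stands clearly at the low end of what has been measured.

Compound 4 `C/N=C(\S)NCCCCCCn1nc(-c2ccccc2)ccc1=O` has not yet been measured in this assay. It differs from compound 2 in one place: hydrogen in place of methyl on a saturated chain carbon bound to a double-bonded nitrogen. Going by the values given here, no pair of measured compounds shows this change on its own; compound 1 and compound 3 differ from each other in several places at once, so their gap says nothing about this change alone. Among the compounds with values here, with so small a change and no comparable step in hand, no step beyond the scatter is expected in this assay, in either direction. The step from compound 2 to compound 4 is therefore estimated as a number 3.6 percentage points higher from compound 2 to compound 4 (within the scatter). For compound 4 the expected value in this assay is -2%, with a range from -18% to 14%.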

Compound 4, a percentage reported as inhibition, in the whole organism at one dose (the size of the read-out at that dose, not a potency): 22.2%
Compound 4: middle estimate off by 24.2 percentage points, on the low side; the whole stated range lies below it.
By their numbers in this assay, from the lowest: compound 2; then compounds 4, 1 and 3 (each within the scatter of the next, the first and the last beyond it).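

Hydrogen in place of methyl on a saturated chain carbon bound to a double-bonded nitrogen, the same difference as ethyl to methyl, gives a number 27.8 percentage points higher from compound 2 to compound 4 (beyond the scatter) in this assay and is the first single-place comparison in the series. This position therefore matters in this assay, although the change removes only one carbon and involves no ring, hydrogen-bond donor, hydrogen-bond acceptor or net charge. Nothing in hand explains the size or direction of this step.

Open, on these data alone, is how a propyl or cyclopropyl group at this place would read in this assay. Also open, as far as these compounds go, is whether ethyl to methyl gives a similar step in the compounds carrying a nitrile, as compound 1 and compound 3 differ from each other in several places at once.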